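A few compounds are considered here, and "the series" means these few. Any claim that something is new, unique, unknown or untested is made for them only; others in the source may bear on it.

Measured in a functional assay on A549 cells (Homo sapiens) for inhibition, read by MTT assay, with a stated time of 48 h; a lower number here means a stronger inhibitor, a higher number a weaker inhibitor:
- compound 1 `CS(=O)(=O)Nc1ccc(-n2cc(COc3ccccc3Cl)nn2)cc1Oc1ccccc1`: 53800 nM
- compound 2 `Cc1cc(OCc2cn(-c3ccc(NS(C)(=O)=O)c(Oc4ccccc4)c3)nn2)ccc1Cl`: 6700 nM

Compound 2, at 6700 nM, holds the lower of the two numbers in this assay and is the stronger inhibitor of the pair. Compound 3 `CS(=O)(=O)Nc1ccc(-n2cc(COc3ccc4ccccc4c3)nn2)cc1Oc1ccccc1` keeps the core of compound 2 and has naphthalen-2-yl in place of 4-chloro-3-methylphenyl on an oxygen on a saturated carbon. Among the compounds with values here, one measured step bears on this change, as it falls at the same place: an 8.0-fold lower number from compound 1 to compound 2 (0.90 log units; beyond the scatter). That modest step shows that the number can move with the group here, but it gives no direction for naphthalen-2-yl. A step of that size or smaller is therefore expected in this assay, with only a slight lean towards a higher number. For compound 3 the estimated value is 10000 nM, with an expected range of 3000 nM to 35000 nM. The expected change is a 1.5-fold higher number from compound 2 to compound 3 (0.17 log units; within the scatter).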

Compound 3, half-maximal inhibitory concentration: 8300 nM
Compound 3: the middle estimate sits 1.2-fold (0.08 log units) above what was measured; measured number inside the range.
By their numbers in this assay, from the lowest: compounds 2 and 3 (each within the scatter of the next); then compound 1.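

In this assay the change to naphthalen-2-yl gives a 1.2-fold higher number from compound 2 to compound 3 (0.09 log units; within the scatter) and so leaves the number where 4-chloro-3-methylphenyl had it, even though naphthalen-2-yl carries no chlorine. Measured against 2-chlorophenyl, the same place gives a 6.5-fold lower number from compound 1 to compound 3 (0.81 log units; beyond the scatter) so two different groups on this oxygen now stand apart from 2-chlorophenyl by steps beyond the scatter, and the chlorine shared by compound 1 and compound 2 does not by itself set the number. Nothing shown here gives a reason for these numbers.

The compounds shown leave open whether 4-chlorophenyl or 3-methylphenyl alone would match 4-chloro-3-methylphenyl, and where unsubstituted phenyl would fall. They also leave open how a phenyl bearing an amine or a carboxylic acid would read at this place.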